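A Two-Compound Starting Point and One Substituent Swap

The source may report more compounds than this note shows. Statements on the series, on what has been measured and on what is new or still open speak of the compounds shown alone.

Compound 1 `Fc1ccc(Nc2cc(Nc3ccc(Oc4ccncc4-c4cccnc4)c(F)c3)ncn2)cc1` and compound 2 `Cn1c(=O)c(C(=O)Nc2ccc(Oc3ccncc3-c3cccnc3)c(F)c2)nn(-c2ccccc2F)c1=O` share a core built around a diaryl ether. In a functional assay on A549 cells (Homo sapiens) for cytotoxicity, read by MTT assay, with a stated time of 72 h (a lower number here means a stronger inhibitor, a higher number a weaker inhibitor), compound 1 gives 710 nM and compound 2 gives 610 nM; the two values sit within the scatter of each other, so neither can be called the stronger. Compound 3 `Cn1c(=O)c(C(=O)Nc2ccc(Oc3ccncc3-c3cccnc3)c(F)c2)nn(-c2cccc(C(F)(F)F)c2)c1=O` differs from compound 2 by 3-(trifluoromethyl)phenyl in place of 2-fluorophenyl on an aromatic nitrogen. Within the data shown here, no measured pair shows what such a swap does, so the expected step of a 1.1-fold lower number from compound 2 to compound 3 (0.04 log units; within the scatter) is small and in no clear direction. Compound 3 is estimated to give 550 nM in this assay, within 150 nM to 2000 nM.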

Compound 3, half-maximal inhibitory concentration: 460 nM
For compound 3 the middle estimate is 1.2-fold (0.08 log units) above the measured one; measured number inside the range.
By their numbers in this assay, from the lowest: compounds 3, 2 and 1 (each within the scatter of the next).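

Among these compounds, this pair gives the first reading at this position on the aromatic nitrogen: in this assay, 3-(trifluoromethyl)phenyl in place of 2-fluorophenyl gives a 1.3-fold lower number from compound 2 to compound 3 (0.12 log units; within the scatter). Although the entering group has 10 heavy atoms and the leaving group 7, the two compounds cannot be told apart in this assay. No measurement shown here offers an explanation for this result. On these data alone, it remains open whether a phenyl ring carrying an amine or a carboxylic acid, or a longer chain in place of the ring, would give a step beyond the scatter.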